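Enlarging the Ring Substituent: Cyclopentyl to Cyclohexyl

This account rests on a few compounds, and the source may have more. Where it says the series, first, only, none or still open, it means among the compounds named here.

Two compounds share a core in which one aromatic carbon carries a small alkyl group. Compound 1 `COC(=O)c1nc(C(C)C)n(-c2ccc(F)cc2)n1` carries an isopropyl group there, while compound 2 `COC(=O)c1nc(C2CCCC2)n(-c2ccc(F)cc2)n1` carries a cyclopentyl group. Both were tested in a functional assay on NPC-TW01 cells (Homo sapiens) for inhibition, read by MTT assay, with a stated time of 72 h; on this read-out higher numbers stand for weaker inhibition of growth and lower numbers for stronger inhibition of growth. In this assay compound 1 gives > 100000 nM, which is a limit of the assay rather than a number. In this assay, within the data shown here, compound 2 gives 10400 nM, the only actual number so far. The change from isopropyl to cyclopentyl gave an at least 9.6-fold lower number from compound 1 to compound 2 (0.98 log units; beyond the scatter). That step is known only as a lower bound because the limit of > 100000 nM in this assay, at which 1 of the 2 values shown sits, is where compound 1 sits.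

Compound 3 `COC(=O)c1nc(C2CCCCC2)n(-c2ccc(F)cc2)n1` has not yet been measured. It differs from compound 2 by cyclohexyl in place of cyclopentyl on an aromatic carbon. Among the measured compounds shown here, the one measured step that bears on this, from compound 1 to compound 2, showed that a larger group in this position went with a lower number, at least modestly. Growing the ring by one atom is a smaller change than that, so for compound 3 in this assay a small downward step or none beyond the scatter is expected, estimated as a 1.7-fold lower number from compound 2 to compound 3 (0.24 log units; within the scatter). Compound 3 is expected to give about 6000 nM in this assay, within the range 2000 nM to 20000 nM.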

Compound 3, concentration for 50% growth inhibition: 30500 nM
Estimate against measurement, compound 3: 5.1-fold (0.71 log units) below; the whole stated range lies below it.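

In this assay, going from the five-membered ring of cyclopentyl to the six-membered ring of cyclohexyl gives a 2.9-fold higher number from compound 2 to compound 3 (0.47 log units; beyond the scatter), so a larger group on this aromatic carbon does not simply go with a lower number, and compound 3 goes against the trend suggested by the first step. Among the three groups, cyclopentyl in compound 2 has the lowest number, yet cyclohexyl still compares well with isopropyl, with an at least 3.2-fold lower number from compound 1 to compound 3 (0.51 log units; beyond the scatter). The true size of that last step stays unknown because compound 1 sits at a limit of the assay, not at a number: the limit of > 100000 nM in this assay, at which 1 of the 3 values shown sits.

From the compounds shown here alone, the three groups are all plain carbon groups, so they show only a narrow slice of what this position might accept, and whether cyclopentyl is a real optimum remains open without a cyclobutyl ring or a longer chain such as n-butyl to compare. It is also unknown how a group with nitrogen or oxygen, such as a piperidine or a tetrahydropyran ring of similar size to cyclohexyl, would behave on this carbon.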